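Notes on the ring-nitrogen cap: acyl versus sulfonyl

The compounds below may be only part of what the source reports. "The series", "measured", "known", "first", "only" and "open" are said of these compounds alone.

Compound 1 `CC(C)OC(=O)N1CCC(COc2ccc(N3CCN(C(=O)N(C)C)CC3)nc2)CC1`: in a functional assay on CHO-K1 cells for agonist activity at Glucose-dependent insulinotropic receptor (Homo sapiens), read by a luciferase reporter, with a stated time of 5 h (a higher number here means that more compound is needed for the effect, a lower number that less compound is needed), compound 1 gives > 10000 nM, a limit.
Compound 2 `CC(=O)N1CCN(c2ccc(OCC3CCN(C(=O)OC(C)C)CC3)cn2)CC1`: in this assay compound 2 gives > 10000 nM, a limit.
Compound 3 `CC(C)OC(=O)N1CCC(COc2ccc(N3CCN(C(=O)c4ccco4)CC3)nc2)CC1`: in this assay compound 3 gives 1900 nM.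

Going by the values given here, compound 3 holds the only number in the set; the other two sit at the limit of > 10000 nM in this assay, at which 2 of the 3 values shown sit. Compound 4 `CCS(=O)(=O)N1CCN(c2ccc(OCC3CCN(C(=O)OC(C)C)CC3)cn2)CC1` differs from compound 3 by ethylsulfonyl in place of (furan-2-yl)carbonyl on an amine nitrogen in a ring. The measured steps that bear on this are an at least 5.2-fold lower number from compound 1 to compound 3 (0.72 log units; beyond the scatter) and an at least 5.2-fold lower number from compound 2 to compound 3 (0.72 log units; beyond the scatter), both showing that the furan-2-yl group on the carbonyl carries the gain over a small cap. Among the compounds with values here, no measured step covers a sulfonyl cap. Removing the furan-2-yl ring is therefore expected to raise the number again, as a 4.2-fold higher number from compound 3 to compound 4 (0.62 log units; beyond the scatter). For compound 4 the estimate in this assay is 8000 nM, within 2500 nM to 30000 nM.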

Compound 4, half-maximal effective concentration: 1300 nM
Compound 4: middle estimate off by 6.2-fold (0.79 log units), on the high side, and the stated range ends above it.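

In this assay, ethylsulfonyl in place of (furan-2-yl)carbonyl gives a 1.5-fold lower number from compound 3 to compound 4 (0.16 log units; within the scatter), so a measurable value at this ring nitrogen does not depend on the furan-2-yl ring. Ethylsulfonyl, with no ring, also gives an at least 7.6-fold lower number from compound 2 to compound 4 (0.88 log units; beyond the scatter) and an at least 7.6-fold lower number from compound 1 to compound 4 (0.88 log units; beyond the scatter). Both of these steps start from a limit and so give only a minimum size: the limit of > 10000 nM in this assay, at which 2 of the 4 values shown sit.

Still open, going by these compounds, is how methylsulfonyl, a longer chain on the sulfonyl, or a benzoyl cap would read at this position.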